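Swapping the aryl group on the core nitrogen

A few compounds are considered here, and "the series" means these few. Any claim that something is new, unique, unknown or untested is made for them only; others in the source may bear on it.

Of the compounds shown here, three sharing one core have been tested in a functional assay on A549 cells (Homo sapiens) for antiproliferative activity, read by MTT assay, with a stated time of 72 h; a higher number here means a weaker inhibitor, a lower number a stronger inhibitor. Compound 1 `O=C(Nc1ccc(Oc2ccnc3[nH]ccc23)c(F)c1)c1cc2cccnc2n(-c2ccc(C(F)(F)F)cc2Cl)c1=O` gives 1020 nM. Compound 2 `Cn1ccc2c(Oc3ccc(NC(=O)c4cc5cccnc5n(-c5ccc(F)c(Cl)c5)c4=O)cc3F)ccnc21` gives 3560 nM, and compound 3 `Cn1ccc2c(Oc3ccc(NC(=O)c4cc5cccnc5n(-c5ccc(Br)cc5F)c4=O)cc3F)ccnc21` gives 2690 nM. Compound 3 thus stands second highest of the three numbers: its gap to compound 2 lies within the scatter, while the gap to compound 1 lies beyond it, compound 1 showing the lower number.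

Among the compounds with values here, the one change among the measured pairs, a 1.3-fold lower number from compound 2 to compound 3 (0.12 log units; within the scatter), stayed within the scatter. Compound 4 `Cn1ccc2c(Oc3ccc(NC(=O)c4cc5cccnc5n(-c5ccc(C(F)(F)F)cc5Cl)c4=O)cc3F)ccnc21` carries the change (2-chloro-4-(trifluoromethyl)phenyl in place of 4-bromo-2-fluorophenyl on an aromatic nitrogen). Within the data shown here, no measured step covers this exact swap. Among the measured compounds shown here, the only guide is that compound 1, which bears the same 2-chloro-4-(trifluoromethyl)phenyl group, gives the lowest number of the three, and that compounds 2 and 3 differ from compound 4 by the same methyl-bearing core. On this basis the step is expected to be a 1.8-fold lower number from compound 3 to compound 4 (0.25 log units; within the scatter), a move downward. Compound 4 is therefore estimated at 1500 nM, with a likely range from 600 nM to 4000 nM in this assay.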

Compound 4, half-maximal inhibitory concentration: 3530 nM
Compound 4: middle estimate off by 2.4-fold (0.37 log units), on the low side, within the range that was stated.
By their numbers in this assay, from the lowest: compound 1; then compounds 3, 4 and 2 (each within the scatter of the next).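

In this assay, the aryl group on the core nitrogen has so far made no readable difference among the methyl-bearing compounds: a 1.3-fold higher number from compound 3 to compound 4 (0.12 log units; within the scatter) and a 1.0-fold lower number from compound 2 to compound 4 (0.00 log units; within the scatter) both lie within the scatter. The clearer result lies elsewhere, since compound 1 and compound 4 share 2-chloro-4-(trifluoromethyl)phenyl and differ only by methyl in place of hydrogen on an aromatic nitrogen, giving a 3.5-fold higher number from compound 1 to compound 4 (0.54 log units; beyond the scatter), so the lower number of compound 1 goes with that hydrogen rather than with its aryl group. No measurement offers a reason for either result.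

Going by these compounds, whether the hydrogen gives the same gap alongside 4-bromo-2-fluorophenyl or 3-chloro-4-fluorophenyl remains open. So does whether a phenyl ring bearing an amine or a carboxylic acid, or a saturated cyclohexyl ring, would separate from these halogen-bearing groups.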